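Chloro in place of acetoxy on the shared core

A few compounds are considered here, and "the series" means these few. Any claim that something is new, unique, unknown or untested is made for them only; others in the source may bear on it.

Measured in a functional assay on DLD-1 cells (Homo sapiens) for cytotoxicity, with a stated time of 48 h; a higher number here means a weaker inhibitor, a lower number a stronger inhibitor:
compound 1, `CC(=O)Oc1ccc2oc(/C=C/[S+](C)[O-])cc(=O)c2c1`: > 10000 nM
compound 2, `C[S+]([O-])/C=C/c1cc(=O)c2ccccc2o1`: 8000 nM
compound 3, `CCCCOc1ccc2oc(/C=C/[S+](C)[O-])cc(=O)c2c1`: 4800 nM

Compound 1 is known only as a limit of this assay, not as a number (the limit of > 10000 nM in this assay, at which 1 of the 3 values shown sits). Compound 4, `C[S+]([O-])/C=C/c1cc(=O)c2cc(Cl)ccc2o1`, has not been measured; it differs from compound 1 in that (chloro in place of acetoxy on an aromatic carbon).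

Two measured steps start from compound 1. Removing the acetoxy gives an at least 1.2-fold lower number from compound 1 to compound 2 (0.09 log units; that floor lies within the scatter), and exchanging the acetyl for butyl on the same oxygen gives an at least 2.0-fold lower number from compound 1 to compound 3 (0.31 log units; beyond the scatter). Compound 2 and compound 3 sit close to each other, with a 1.7-fold lower number from compound 2 to compound 3 (0.22 log units; within the scatter). Both steps away from the acetoxy thus leave the limit behind, and any change at this position among the measured compounds lands within a narrow band of numbers. For chloro at the same carbon a step of at least the same kind is expected, downward and modest.

Compound 4 is therefore estimated at 6000 nM, within 2500 nM to 15000 nM. This estimate amounts to an expected at least 1.6-fold lower number from compound 1 to compound 4 (0.22 log units; that floor lies within the scatter).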

Compound 4, half-maximal inhibitory concentration: 6500 nM
Estimate against measurement, compound 4: 1.1-fold (0.03 log units) below; the range from low to high includes it.
By their numbers in this assay, from the lowest: compounds 3, 4 and 2 (each within the scatter of the next). At a limit, above all of these: compound 1.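

In this assay, chloro at this aromatic carbon cannot be told apart from hydrogen or butoxy (a 1.2-fold lower number from compound 2 to compound 4 (0.09 log units; within the scatter); a 1.4-fold higher number from compound 3 to compound 4 (0.13 log units; within the scatter)), so the series now holds three groups at this carbon that the assay does not separate, although chloro has a single heavy atom and no hydrogen-bond acceptor. The exchange of acetoxy for chloro gives only a floor (an at least 1.5-fold lower number from compound 1 to compound 4 (0.18 log units; that floor lies within the scatter)), so this step, unlike the exchange of acetyl for butyl on the oxygen, does not by itself set its two compounds apart beyond the scatter. Compound 1 remains a limit and not a number: the limit of > 10000 nM in this assay, at which 1 of the 4 values shown sits.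

As far as these compounds go, how far acetoxy really lies from the other three groups stays open. Also open, from the compounds shown here alone, is whether an amine, a carboxylic acid or a chain longer than butoxy at this carbon would leave the narrow band.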